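This account rests on a few compounds, and the source may have more. Where it says the series, first, only, none or still open, it means among the compounds named here.

Within the data shown here, compound 2 `COC(=O)C1=C(C)NC(C)=C(C(=O)OC)C1c1c(-c2cccnc2)nc2sccn12` gives 3550 nM in a functional assay on ileum (Cavia porcellus) for inhibition (on this read-out higher numbers stand for weaker inhibition and lower numbers for stronger inhibition), the higher of the two numbers measured so far. Compound 1 `COC(=O)C1=C(C)NC(C)=C(C(=O)OC)C1c1c(-c2ccccn2)nc2sc(C)cn12` differs from compound 2 in two places; in this assay compound 1 gives 2810 nM, and the two values lie within the scatter of each other, so no order can be read from them. Compound 3 `COC(=O)C1=C(C)NC(C)=C(C(=O)OC)C1c1c(-c2cccnc2)nc2sc(C)cn12` has not yet been measured. It differs from compound 2 by a single change: methyl in place of hydrogen on an aromatic carbon. Among the measured compounds shown here, no pair of measured compounds that differ in only one place is available, so the size of this step cannot be read from a measured example. Compound 1 carries the same methyl on its five-membered aromatic ring, and because compound 1 gives 2810 nM while compound 2 gives 3550 nM, with the two values within the scatter, a large move is not indicated. The step of a 1.2-fold lower number from compound 2 to compound 3 (0.07 log units; within the scatter) is therefore expected to stay within the scatter, in either direction. Compound 3 is estimated at 3000 nM in this assay, within a range of 1200 nM to 7500 nM.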

Compound 3, half-maximal inhibitory concentration: 16000 nM
Beside the measured number, compound 3's estimate is 5.3-fold (0.73 log units) below it; the whole stated range lies below it.
By their numbers in this assay, from the lowest: compounds 1 and 2 (each within the scatter of the next); then compound 3.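

In this assay, methyl in place of hydrogen on an aromatic carbon next to the ring sulfur is not a silent change: with the pyridin-3-yl group present, it gives a step beyond the scatter (a 4.5-fold higher number from compound 2 to compound 3 (0.65 log units; beyond the scatter)). Among these compounds, this is the first reading of this position from a pair differing in one place, and it shows weaker inhibition with the methyl present. With that methyl held constant, pyridin-3-yl in place of pyridin-2-yl also moves the number beyond the scatter (a 5.7-fold higher number from compound 1 to compound 3 (0.76 log units; beyond the scatter)), so the attachment of the pyridine ring matters in this series as well.

Still open, from the compounds shown here alone, is whether the methyl step carries over to the pyridin-2-yl compounds, and whether ethyl, chlorine or hydroxymethyl on this carbon would move the number further. No measurement at hand accounts for either step.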